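Swapping the Methoxyphenyl Arm Back for a Methylphenyl

The source may hold more compounds than are shown below. What is called first, only, known or untested is meant among the compounds shown, and "the series" means these compounds.

Measured so far:
Compound 1, `C=CCn1c(=O)/c(=C\c2cccc(C)c2)[nH]c(=O)/c1=C\c1ccccc1OC`: 19300 nM
Compound 2, `C=CCn1c(=O)/c(=C\c2cccc(Br)c2)[nH]c(=O)/c1=C\c1ccccc1OC`: 5400 nM
Compound 3, `C=CCn1c(=O)/c(=C\c2ccccc2OC)[nH]c(=O)/c1=C\c1ccccc1OC`: 6900 nM

All three compounds share the core of compound 1 and were tested in a functional assay on HeLa cells (Homo sapiens) for cytotoxicity, read by CCK-8 assay, with a stated time of 72 h; a lower number here means a stronger inhibitor, a higher number a weaker inhibitor. Compound 3 gives 6900 nM, the second highest of the three numbers; its nearest neighbour is compound 2, and the gap a 1.3-fold higher number from compound 2 to compound 3 (0.11 log units; within the scatter) lies within the scatter, so no order between them can be read. Compound 1 is further away: a 2.8-fold lower number from compound 1 to compound 3 (0.45 log units; beyond the scatter).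

Compound 4, `C=CCn1c(=O)/c(=C\c2ccc(C)cc2)[nH]c(=O)/c1=C\c1ccccc1OC`, differs from compound 3 in one place: 4-methylphenyl in place of 2-methoxyphenyl on a double-bonded chain carbon bound to an aromatic carbon. Among the measured compounds shown here, only one measured step bears on this: a 2.8-fold lower number from compound 1 to compound 3 (0.45 log units; beyond the scatter), where a 2-methoxyphenyl replaced a 3-methylphenyl and lowered the number modestly. Compound 4 reverses that exchange, but with the methyl now on a 4-methylphenyl, for which no measured comparison exists. The expectation is therefore a modest move back toward compound 1, a higher number, of about the size of that earlier step, and this is what a 1.9-fold higher number from compound 3 to compound 4 (0.28 log units; within the scatter) expresses.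

Compound 4 is estimated at 13000 nM, with a likely range from 5000 nM to 35000 nM.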

Compound 4, half-maximal inhibitory concentration: "not active" (no number reported)
Compound 4: no number reported, and the estimate cannot be compared.
By their numbers in this assay, from the lowest: compounds 2 and 3 (each within the scatter of the next); then compound 1.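

Among the compounds shown here, compound 4 is reported only as not active, with no number, so no step from compound 3 to compound 4 can be read. The compounds shown leave open how the 4-methylphenyl group compares with the 2-methoxyphenyl group on the shared core. Nothing available explains this result.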